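Amide substituent swaps on a shared hexafluoro-carbinol naphthol core

The compounds below may be only part of what the source reports. "The series", "measured", "known", "first", "only" and "open" are said of these compounds alone.

Compound 1 `O=C(COc1ccc2cc(C(O)(C(F)(F)F)C(F)(F)F)c(O)cc2c1)Nc1nc2ccccc2s1` gives 9900 nM in an assay on isolated protein for inhibition of tyrosine-protein phosphatase non-receptor type 13 (Homo sapiens), read by spectrophotometry; a higher number here means a weaker inhibitor, a lower number a stronger inhibitor. Compound 2 `O=C(COc1ccc2cc(C(O)(C(F)(F)F)C(F)(F)F)c(O)cc2c1)NCc1ccccc1` gives > 20000 nM in this assay, which is a limit of the assay and not a number. Compound 3 `O=C(COc1ccc2cc(C(O)(C(F)(F)F)C(F)(F)F)c(O)cc2c1)Nc1cccc2ccccc12` gives > 20000 nM in this assay, again a limit of the assay and not a number. Compound 3 therefore stands at the upper edge of what this assay reports, and two of the three values sit there (the limit of > 20000 nM in this assay, at which 2 of the 3 values shown sit).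

Compound 4 `O=C(COc1ccc2cc(C(O)(C(F)(F)F)C(F)(F)F)c(O)cc2c1)NC1CC1` differs from compound 3 by cyclopropyl in place of naphthalen-1-yl on an amide-type nitrogen. Among the measured compounds shown here, the steps that bear on a change at this amide nitrogen are an at least 2.0-fold higher number from compound 1 to compound 2 (0.30 log units; that floor lies within the scatter) and an at least 2.0-fold higher number from compound 1 to compound 3 (0.30 log units; that floor lies within the scatter), both of which run into the limit; the step that the two limits leave unreadable from compound 2 to compound 3 shows nothing usable. Every substituent yet tried on that nitrogen other than 1,3-benzothiazol-2-yl has given a limit, so for compound 4 a value at or near the limit in this assay is expected, with no readable step, a step that the limit leaves unreadable from compound 3 to compound 4. Compound 4 is estimated at 25000 nM, within 8000 nM to 60000 nM.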

Compound 4, half-maximal inhibitory concentration: > 20000 nM
Compound 4: no number, only a limit; the forecaster's own chance of this, stated with the estimate: 70%; the middle value is on the limit's open side.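

Compound 4 gives > 20000 nM in this assay, again a limit of the assay and not a number. Cyclopropyl, with 3 heavy atoms and no aromatic ring, ends at the same limit as naphthalen-1-yl, with 10 heavy atoms, and as benzyl, so compound 1 with 1,3-benzothiazol-2-yl remains the only exception, with an at least 2.0-fold higher number from compound 1 to compound 4 (0.30 log units; that floor lies within the scatter). The steps among compounds 2, 3 and 4 cannot be read, and the series now gathers at the edge of the read-out: the limit of > 20000 nM in this assay, at which 3 of the 4 values shown sit.

Open, as far as these compounds go, is whether a thiazol-2-yl or pyridin-2-yl group on the amide-type nitrogen would, like the group in compound 1, give a value that can be read. Also open, from the compounds shown here alone, are how far compounds 2, 3 and 4 lie past the limit and whether a carboxylic acid on the benzothiazole would shift compound 1.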